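Methyl on the Amide Nitrogen of Compound 3

The source may report more compounds than this note shows. Statements on the series, on what has been measured and on what is new or still open speak of the compounds shown alone.

Among the measured compounds shown here, compound 3 `NC(=O)C1CCN(c2nc(-c3cc(F)c(Cl)cc3F)nc3c2CS(=O)(=O)C3)CC1` gives 3 mg/kg in a functional assay on the whole organism (blood, strain ICR) with Mus musculus as the target, in the glucose tolerance test, with a stated time of 30 min (a lower number here means that less compound is needed, a higher number that more compound is needed for the effect), the highest of the three numbers measured so far. Compound 1 `O=S1(=O)Cc2nc(-c3cc(F)c(Cl)cc3F)nc(N3CCC(CO)CC3)c2C1` gives 0.3 mg/kg, and compound 2 `NC(=O)CC1CCN(c2nc(-c3cc(F)c(Cl)cc3F)nc3c2CS(=O)(=O)C3)CC1` gives 0.1 mg/kg. Both steps to compound 3 lie beyond the scatter: a 10-fold higher number from compound 1 to compound 3 (1.00 log units; beyond the scatter) and a 30-fold higher number from compound 2 to compound 3 (1.48 log units; beyond the scatter). The remaining step, a 3.0-fold lower number from compound 1 to compound 2 (0.48 log units; beyond the scatter), is smaller.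

Compound 4 `CNC(=O)C1CCN(c2nc(-c3cc(F)c(Cl)cc3F)nc3c2CS(=O)(=O)C3)CC1` differs from compound 3 by methyl in place of hydrogen on an amide-type nitrogen. For the measured compounds named here, none of the measured steps touches the amide nitrogen; each exchanges the whole group on the saturated ring carbon, so they show that this region of the molecule matters in this assay without saying how a methyl on the nitrogen would act. The expectation therefore rests on compound 3 alone, with wide uncertainty in either direction. Compound 4 is expected to give about 3 mg/kg in this assay, within a range from 1 mg/kg to 10 mg/kg. The expected step of no change at the digits printed from compound 3 to compound 4 (within the scatter) is thus none beyond the scatter.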

Compound 4, minimum effective dose: 3 mg/kg
The estimate for compound 4 equals the measured number at the digits printed; the measured number falls inside the stated range.
By their numbers in this assay, from the lowest: compound 2; then compound 1; then compounds 3 and 4 (each within the scatter of the next).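

In this assay methyl in place of the amide hydrogen gives no change at the digits printed from compound 3 to compound 4 (within the scatter) and is thus the first change shown on the amide-type nitrogen itself, one that stays within the scatter. The methylcarbamoyl group also leaves the wide gaps to the other two groups on the saturated ring carbon in place, with a 30-fold higher number from compound 2 to compound 4 (1.48 log units; beyond the scatter) and a 10-fold higher number from compound 1 to compound 4 (1.00 log units; beyond the scatter) as its steps from carbamoylmethyl and hydroxymethyl. Nothing given here explains why the methyl on this nitrogen leaves the number where it stands.

The compounds shown leave open whether a second methyl or a longer chain on this nitrogen would act in the same way, and whether methyl on the amide nitrogen of compound 2 would also stay within the scatter. They also leave open how a carboxylic acid or an amine on the saturated ring carbon would read in this assay here.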